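The compounds below may be only part of what the source reports. "The series", "measured", "known", "first", "only" and "open" are said of these compounds alone.

Compound 1, with the structure `CCc1ccccc1NC(=O)N[C@H](C)c1ccccc1`, was tested in an ADME assay on the whole organism with Oryza sativa as the target, tested at 1 uM (a higher number here means a weaker effect of the compound at the concentration tested, a lower number a stronger effect), and gave 100%. Within the data shown here, of the two numbers measured so far this is the higher, and its nearest neighbour is compound 2, the structure `C[C@@H](NC(=O)Nc1ccccc1F)c1ccccc1`, which in this assay gave 95%. Among the measured compounds shown here, the one step recorded between measured compounds, a number 5 percentage points lower from compound 1 to compound 2 (within the scatter), lies within the scatter, so the two values cannot be told apart.

Compound 3, the structure `CCc1cccc(CC)c1NC(=O)N[C@H](C)c1ccccc1`, has not yet been measured in this assay. It differs from compound 1 in a single place: ethyl in place of hydrogen on an aromatic carbon. For the measured compounds named here, the only measured step exchanges one group for another at a different position and is within the scatter, so it offers no direct guide to adding a second ethyl; compound 3 is therefore expected to stay near compound 1, with a number 3 percentage points lower from compound 1 to compound 3 (within the scatter) no larger than the scatter. The estimate for compound 3 in this assay is 97%, expected to fall between 82% and 100%.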

Compound 3, a percentage reported as activity, at one concentration (the size of the read-out at that concentration, not a potency): 101%
For compound 3 the middle estimate is 4 percentage points below the measured one; measured number above the stated range.
By their numbers in this assay, from the lowest: compounds 2, 1 and 3 (each within the scatter of the next).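

In this assay, ethyl in place of hydrogen on an aromatic carbon, ortho to a large group and meta to an ethyl group, gives a number 1 percentage points higher from compound 1 to compound 3 (within the scatter), so the two compounds cannot be told apart. The earlier step exchanged one group for another elsewhere on the ring, whereas this one shows that, at this newly tested position, an ethyl group can stand in place of hydrogen with no difference beyond the scatter. No measurement shown bears on why this step is so small.

Still open, as far as these compounds go, is whether a different group at this position, such as a methoxy group, an amine, a carboxylic acid or a longer chain, would shift the number in this assay beyond the scatter. Equally open, from the compounds shown here alone, is whether the same ethyl group would give a like result on compound 2, which carries fluoro in place of the first ethyl.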